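From ethenyl to cyclopropyl on a shared core

This account rests on a few compounds, and the source may have more. Where it says the series, first, only, none or still open, it means among the compounds named here.

In a functional assay on A2780 cells (Homo sapiens) for antiproliferative activity, read by CellTiter-Glo, with a stated time of 4 days (a lower number here means a stronger inhibitor, a higher number a weaker inhibitor), compound 1 (`Nc1ccc(CNC(=O)Nc2ccc(CN3C(=O)c4ccccc4C3=O)cc2)cn1`) gives 7 nM as its result. Compound 2 (`O=C(/C=C/c1cccnc1)Nc1ccc(CN2C(=O)c3ccccc3C2=O)cc1`) has no single number, its entry reading "not determined" (no result reported) and nothing more. The change to compound 3 (`O=C(Nc1ccc(CN2C(=O)c3ccccc3C2=O)cc1)[C@@H]1C[C@H]1c1cccnc1`) puts 2-(pyridin-3-yl)cyclopropyl in place of 2-(pyridin-3-yl)ethenyl on a carbonyl carbon. Among the measured compounds shown here, compound 2 offers no starting value in this assay, so the expectation is of no step beyond the scatter, in either direction, and the only guide is compound 1 at 7 nM on the same core. For compound 3 the expected value is 6 nM, with an estimated range of 1 nM to 40 nM for the measurement.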

Compound 3, half-maximal inhibitory concentration: > 2500 nM
Compound 3: no number, only a limit (the forecaster's own chance of this, stated with the estimate: 3%); at least 410-fold (2.61 log units) between middle value and limit.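

In this assay compound 3 gives only a limit, > 2500 nM, not a number. On the carbonyl carbon, 2-(pyridin-3-yl)cyclopropyl in place of ((6-aminopyridin-3-yl)methyl)amino gives an at least 350-fold higher number from compound 1 to compound 3 (2.55 log units; beyond the scatter), so the result on the shared core depends strongly on the group at this place. Compound 2 has no result, so the step from ethenyl to cyclopropyl cannot be read. The compounds shown leave open how a plain primary amine or a carboxylic acid on this carbonyl carbon would fare. They also leave open whether the mirror-image cyclopropyl would give a measurable number.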